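The source may hold more compounds than are shown below. What is called first, only, known or untested is meant among the compounds shown, and "the series" means these compounds.

Among the measured compounds shown here, three related compounds have numbers so far in a functional assay on aorta (Rattus norvegicus, strain Wistar) (a higher number here means a weaker inhibitor, a lower number a stronger inhibitor), and they make a useful starting set. Compound 1 (`Cc1ccc2c(c1)N(C1=CCCC1=O)CC(C)(C)S2`) stands at 933 nM on this scale, compound 2 (`CC1(C)CN(C2=CCCC2=O)c2cc(N)ccc2S1`) at 3980 nM and compound 3 (`CC1(C)CSc2ccc(C(F)(F)F)cc2N1C1=CCCC1=O`) at 66.1 nM on the same scale. Compound 2 holds the highest number of the three, which makes it the weakest inhibitor among them.

Compound 4 (`CC1(C)CN(C2=CCCC2=O)c2cc(C(F)(F)F)ccc2S1`) keeps the core of compound 2 and differs in one place, with trifluoromethyl in place of amino on an aromatic carbon. For the measured compounds named here, one measured step touches this change: amino in place of methyl on an aromatic carbon gave a 4.3-fold higher number from compound 1 to compound 2 (0.63 log units; beyond the scatter) and so was modest but beyond the scatter. That step points to a lower number once amino leaves, yet it involves no trifluoromethyl and cannot set the size. Going by the values given here, compound 3 does carry trifluoromethyl, and compound 3 at 66.1 nM lies far under compound 2, but its core is not identical and no measured step connects the two.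

A larger step than the amino-for-methyl one is therefore expected, towards a lower number. The expected step is a 25-fold lower number from compound 2 to compound 4 (1.40 log units; beyond the scatter) in this estimate. For compound 4 an estimated 160 nM is expected, with 40 nM to 640 nM as the likely range.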

Compound 4, half-maximal inhibitory concentration: 0.0417 nM
Compound 4: middle estimate off by 3800-fold (3.58 log units), on the high side; the whole stated range lies above it.
By their numbers in this assay, from the lowest: compound 4; then compound 3; then compound 1; then compound 2.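

At this aromatic carbon, the choice of group matters far more than the earlier amino and methyl pair could suggest: trifluoromethyl in place of amino gives a 95000-fold lower number from compound 2 to compound 4 (4.98 log units; beyond the scatter) in this assay and that far outstrips the earlier step of a 4.3-fold higher number from compound 1 to compound 2 (0.63 log units; beyond the scatter) at the same carbon. The drop is also more than the loss of amino, since trifluoromethyl in place of methyl, a change with no amino involved, still gives a 22000-fold lower number from compound 1 to compound 4 (4.35 log units; beyond the scatter) in this assay and so trifluoromethyl stands well apart from both other groups here. On this core and at this carbon, the three groups run from the highest number to the lowest as amino, methyl, trifluoromethyl, and the steps along that order are very uneven in size.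

No measurement given here speaks to what lies behind a change of this size. As far as these compounds go, it also remains open whether a nitrile, a chlorine atom or a longer chain such as ethyl at this carbon would reach a number as low as that of trifluoromethyl, or whether trifluoromethyl would keep its effect on another carbon of the same aromatic ring.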